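The compounds below may be only part of what the source reports. "The series", "measured", "known", "first", "only" and "open" are said of these compounds alone.

Two compounds of the series have numbers in an assay on the whole organism (plasma, strain Sprague-Dawley) for inhibition of Dipeptidyl peptidase 4 (Rattus norvegicus), with a stated time of 10 h, at a dose of 1 mg/kg by the oral route; on this read-out lower numbers stand for less inhibition and higher numbers for more inhibition at the one dose given (going by the name of the read-out). Compound 1 `N#C[C@@H]1CCCN1C(=O)[C@@H]1C[C@H](C(=O)N2CCOCC2)CN1` gives 44%. Compound 2 `C[C@@H]1N[C@H](C(=O)N2CCC[C@H]2C#N)C[C@@H]1C(=O)N1CCOCC1` gives 85%. Among the compounds with values here, the one step between them, a number 41 percentage points higher from compound 1 to compound 2 (beyond the scatter), rests on methyl in place of hydrogen on a saturated ring carbon. Within the data shown here, compound 2 therefore stands highest of the two numbers known, with compound 1 as its only neighbour, a number well lower and beyond the scatter.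

Compound 3 `C[C@@H]1N[C@H](C(=O)N2CCC[C@H]2C#N)C[C@@H]1C(=O)N1CCSCC1` has not been measured in this assay. Its change from compound 2 is thiomorpholin-4-yl in place of morpholin-4-yl on a carbonyl carbon. Among the measured compounds shown here, no measured step touches the group on this carbonyl carbon: the single step known, a number 41 percentage points higher from compound 1 to compound 2 (beyond the scatter), concerns the methyl on the saturated ring carbon and carries no information about exchanging morpholin-4-yl for thiomorpholin-4-yl. Both groups are six-membered non-aromatic rings with two hetero atoms, no hydrogen-bond donors and one acceptor, so the step in this assay is expected to stay within the scatter, with a slight lean towards lower numbers allowed for in the range. Compound 3 is expected to give 78% in this assay, within 58% to 92%. The estimated step is a number 7 percentage points lower from compound 2 to compound 3 (within the scatter).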

Compound 3, a percentage reported as inhibition, in the whole organism at one dose (the size of the read-out at that dose, not a potency): 85%
Estimate against measurement, compound 3: 7 percentage points below; measured number inside the range.
By their numbers in this assay, from the lowest: compound 1; then compounds 2 and 3 (each within the scatter of the next).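

In this assay, within the data shown here, thiomorpholin-4-yl in place of morpholin-4-yl on the carbonyl carbon gives no change at the digits printed from compound 2 to compound 3 (within the scatter), the first reading at this position, so the high number of compound 2 survives this exchange at the one dose and time tested. The earlier step, a number 41 percentage points higher from compound 1 to compound 2 (beyond the scatter), concerned only the methyl on the saturated ring carbon, whereas this step shows that the read-out does not separate these two rings, which have the same counts of heavy atoms, donors and acceptors and differ in one ring atom, oxygen or sulfur. As a single-dose percentage, this equality is not a statement of equal potency, and nothing measured here offers an explanation for the result.

The compounds shown leave open whether the carbonyl carbon keeps this number with a group of a different kind, such as a piperazine with its free ring amine, a plain dimethylamine amide or a carboxylic acid. They also leave open whether the methyl step seen with morpholin-4-yl carries over to thiomorpholin-4-yl, and whether an ethyl group could stand in for the methyl on the saturated ring carbon.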